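A few compounds are considered here, and "the series" means these few. Any claim that something is new, unique, unknown or untested is made for them only; others in the source may bear on it.

Measured compounds:
compound 1 `O=C(c1ccc(Cl)cc1)N1CCC(NS(=O)(=O)c2cc(S(=O)(=O)c3ccccc3)ccc2C(F)(F)F)CC1` 1800 nM
compound 2 `O=S(=O)(NC1CCN(S(=O)(=O)c2ccccc2)CC1)c1cc(S(=O)(=O)c2ccccc2)ccc1C(F)(F)F` 210 nM
compound 3 `CC(C)(O)CCN1CCC(NS(=O)(=O)c2cc(S(=O)(=O)c3ccccc3)ccc2C(F)(F)F)CC1` 630 nM

In an assay on U2OS cells for inhibition of secreted frizzled-related protein 1 (Homo sapiens), read by a luciferase reporter, with a stated time of 18 h (on this read-out lower numbers stand for an effect already at smaller amounts and higher numbers for an effect only at larger amounts of compound), compound 1 gives the highest of the three numbers; compound 3 lies nearest, compound 2 furthest. Compound 4 `CC(C)(C)OC(=O)N1CC[C@H](C(=O)N2CCC(NS(=O)(=O)c3cc(S(=O)(=O)c4ccccc4)ccc3C(F)(F)F)CC2)C1` differs from compound 1 by 1-(tert-butoxycarbonyl)pyrrolidin-3-yl in place of 4-chlorophenyl on a carbonyl carbon. Within the data shown here, no measured step alters only this part; the closest are an 8.6-fold lower number from compound 1 to compound 2 (0.93 log units; beyond the scatter) and a 2.9-fold lower number from compound 1 to compound 3 (0.46 log units; beyond the scatter), which replace the whole (4-chlorophenyl)carbonyl on the ring amine nitrogen and both give modest lower numbers. Those steps show that varying this position can lower the number, but none keeps the carbonyl, so the expectation is a step of a 1.8-fold lower number from compound 1 to compound 4 (0.26 log units; within the scatter), small and lower in direction, possibly within the scatter. Compound 4 is estimated at 1000 nM, between 300 nM and 3500 nM.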

Compound 4, half-maximal effective concentration: 150 nM
Compound 4: the middle estimate sits 6.7-fold (0.82 log units) above what was measured; the whole stated range lies above it.
By their numbers in this assay, from the lowest: compounds 4 and 2 (each within the scatter of the next); then compound 3; then compound 1.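

In this assay, the carbonyl on the ring amine nitrogen stays and only the group on it changes, yet this gives a 12-fold lower number from compound 1 to compound 4 (1.08 log units; beyond the scatter) and is a large step. Among these compounds, the earlier steps replaced the whole (4-chlorophenyl)carbonyl, so this is the first sign that the number can fall sharply with the carbonyl kept. Nothing available explains why this change lowers the number. From the compounds shown here alone, whether a free pyrrolidine amine or an acetyl group in place of the tert-butoxycarbonyl would hold this level stays open. Going by these compounds, the part played by the defined stereocentre also stays open.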